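Removing the bromine from compound 2: an expectation

The compounds below may be only part of what the source reports. "The series", "measured", "known", "first", "only" and "open" are said of these compounds alone.

Measured so far in an assay on CHO cells for displacement of a labelled ligand from adenosine receptor A3 (Homo sapiens), read by radioligand binding; a lower number here means a stronger inhibitor, a higher number a weaker inhibitor:
Compound 1, `CCOc1cccc2cc(-c3ccc(Br)cc3)c(=O)oc12`, gives only the assay limit > 100000 nM.
Compound 2, `O=c1oc2c(O)cccc2cc1-c1ccc(Br)cc1`, gives 258 nM.
Compound 3, `COc1cc(-c2cc3cccc(C)c3oc2=O)cc(OC)c1OC`, gives 9820 nM.

Within the data shown here, of the two numbers in hand, compound 2 has the lowest; its nearest neighbour is compound 3, which differs from it in several places at once, so their two values show only that compound 3 sits well higher. Among the measured compounds shown here, the single step that can be followed one change at a time is an at least 380-fold lower number from compound 1 to compound 2 (2.58 log units; beyond the scatter), the exchange of ethyl for hydrogen on the ring oxygen; compound 1 sits at the limit of > 100000 nM in this assay, at which 1 of the 3 values shown sits, so the true size of that step is not known.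

Compound 4, `O=c1oc2c(O)cccc2cc1-c1ccccc1`, is the next compound to be measured. The change from compound 2 is hydrogen in place of bromo on an aromatic carbon. For the measured compounds named here, no measured step touches the aryl group, so nothing in hand bears directly on this change. The bromo is the only substituent on that ring, and its removal is taken here as likely to cost some affinity rather than none. Compound 4 is therefore expected to give 1000 nM in this assay, between 250 nM and 4000 nM. That estimate means a step of a 3.9-fold higher number from compound 2 to compound 4 (0.59 log units; beyond the scatter).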

Compound 4, inhibition constant: 5090 nM
For compound 4 the middle estimate is 5.1-fold (0.71 log units) below the measured one; measured number outside the range, above it.
By their numbers in this assay, from the lowest: compound 2; then compounds 4 and 3 (each within the scatter of the next). At a limit, above all of these: compound 1.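

In this assay the exchange of bromo for hydrogen gives a 20-fold higher number from compound 2 to compound 4 (1.30 log units; beyond the scatter), so this aromatic carbon, para to a large group, is far from indifferent to what it carries. The earlier compounds shown here showed a single followable change, on the ring oxygen of the core, and left the aryl ring untested; the low number of compound 2 is now seen to depend on the bromo as well as on the hydrogen on that oxygen, since losing either one raises the number beyond the scatter. The compounds in hand offer no measurement that would account for the size of this step.

Going by these compounds, what stays open is whether the bromo itself is needed or whether any group on this carbon would serve: chlorine, fluorine, a methyl, a methoxy or an amine in its place would each begin to separate those readings. On these data alone, it is also open whether the bromo step would have the same size on a core carrying a methyl or a longer ether chain on the ring oxygen, or with the bromo moved to another carbon of the same ring.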